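Ester series on the shared core: oral tail flick at one dose

The source may hold more compounds than are shown below. What is called first, only, known or untested is meant among the compounds shown, and "the series" means these compounds.

Three compounds share one core and differ in the amino acid part. Compound 1 `CC[C@H](C)[C@H](NC(=O)CN(c1nc(Cl)nc2[nH]cnc12)C1CC1)C(=O)O` gives 27.4% in a functional assay on the whole organism (Tail, strain ICR) with Mus musculus as the target, in the tail flick test, with a stated time of 90 min, at a dose of 25 umol/kg by the oral route; on this read-out higher numbers stand for a stronger effect at the one dose given and lower numbers for a weaker effect. Compound 2 `C[C@@H](O)[C@H](NC(=O)CN(c1nc(Cl)nc2[nH]cnc12)C1CC1)C(=O)OCc1ccccc1` gives 29.9%, the second highest of the three numbers, within the scatter of both neighbours. Compound 3 `C[C@@H](O)[C@H](NC(=O)CN(c1nc(Cl)nc2[nH]cnc12)C1CC1)C(=O)O` gives 35.9%. The step of a number 8.5 percentage points higher from compound 1 to compound 3 (within the scatter) and the step of a number 6 percentage points higher from compound 2 to compound 3 (within the scatter) are both within the scatter.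

Compound 4 `CC[C@H](C)[C@H](NC(=O)CN(c1nc(Cl)nc2[nH]cnc12)C1CC1)C(=O)OCc1ccccc1` is not yet measured. It differs from compound 2 by ethyl in place of hydroxy on a saturated chain carbon bound to two saturated chain carbons. Within the data shown here, the only step bearing on it is the one from compound 1 to compound 3, run backwards; since a number 8.5 percentage points higher from compound 1 to compound 3 (within the scatter) stays within the scatter, no change beyond the scatter is expected. For compound 4 the expected step is a number 6.9 percentage points lower from compound 2 to compound 4 (within the scatter), and its value is estimated at 23% with a range of 9% to 38%.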

Compound 4, a percentage reported as activity, at one dose (the size of the read-out at that dose, not a potency): 36.3%
Compound 4: the middle estimate sits 13.3 percentage points below what was measured; the range from low to high includes it.
By their numbers in this assay, from the lowest: compounds 1, 2, 3 and 4 (each within the scatter of the next).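

Ethyl in place of hydroxy on a saturated chain carbon bound to two saturated chain carbons gives a number 6.4 percentage points higher from compound 2 to compound 4 (within the scatter), and benzyl in place of hydrogen on the oxygen gives a number 8.9 percentage points higher from compound 1 to compound 4 (within the scatter). Each single step is small, but the size and direction of the change at this position depend on what the oxygen carries: the same change on two cores in this assay, a number 8.5 percentage points higher (within the scatter) from compound 1 to compound 3 and a number 6.4 percentage points lower (within the scatter) from compound 4 to compound 2, 14.9 percentage points apart, beyond the scatter of two such steps. The benzyl change likewise depends on whether the chain carries 1-hydroxyethyl or sec-butyl: the same change on two cores in this assay, a number 6 percentage points higher (within the scatter) from compound 2 to compound 3 and a number 8.9 percentage points lower (within the scatter) from compound 4 to compound 1, 14.9 percentage points apart, beyond the scatter of two such steps.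

On these data alone, whether this dependence holds for other groups stays open. An amine or a longer chain on this carbon, or a methyl group on the oxygen, would test it.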